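A few compounds are considered here, and "the series" means these few. Any claim that something is new, unique, unknown or untested is made for them only; others in the source may bear on it.

Compound 3 `CCCCCCCOc1c(-c2cc(OC)c(OC)c(OC)c2)oc2ccccc2c1=O`, the heptyloxy member, gives > 50000 nM in a functional assay on PC-3 cells (Homo sapiens) for antiproliferative activity, read by WST assay, with a stated time of 3 days (a higher number here means a weaker inhibitor, a lower number a stronger inhibitor), and this is a limit of the assay, not a number. Its standing is thus only (the limit of > 50000 nM in this assay, at which 1 of the 3 values shown sits). Numbers exist for two other chains: compound 1 `CCOc1c(-c2cc(OC)c(OC)c(OC)c2)oc2ccccc2c1=O` gives 900 nM, and compound 2 `CCCCCOc1c(-c2cc(OC)c(OC)c(OC)c2)oc2ccccc2c1=O` gives 22200 nM.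

Compound 4 `CCCC(C)Oc1c(-c2cc(OC)c(OC)c(OC)c2)oc2ccccc2c1=O` is not yet measured. It carries 1-methylbutyl in place of heptyl on an oxygen on an aromatic ring. No branched chain has been measured so far.

Going by the values given here, three steps bear on the change, and in all of them a longer straight chain gives a higher number: a 25-fold higher number from compound 1 to compound 2 (1.39 log units; beyond the scatter), an at least 55-fold higher number from compound 1 to compound 3 (1.74 log units; beyond the scatter) and an at least 2.2-fold higher number from compound 2 to compound 3 (0.35 log units; beyond the scatter). None of the three compounds goes against this trend. Undoing part of an at least 2.2-fold higher number from compound 2 to compound 3 (0.35 log units; beyond the scatter) points to a lower number in this assay, near that of compound 2 at 22200 nM, with the effect of branching unknown.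

The expected change is a modest or larger drop, estimated as an at least 3.3-fold lower number from compound 3 to compound 4 (0.52 log units; beyond the scatter). For compound 4 the estimated value is 15000 nM, with an expected range of 5000 nM to 45000 nM.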

Compound 4, half-maximal inhibitory concentration: 49300 nM
Beside the measured number, compound 4's estimate is 3.3-fold (0.52 log units) below it, outside the stated range (above it).
By their numbers in this assay, from the lowest: compound 1; then compound 2; then compound 4. At a limit, above all of these: compound 3.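

In this assay, 1-methylbutyl in place of pentyl gives a 2.2-fold higher number from compound 2 to compound 4 (0.35 log units; beyond the scatter). The shorter, branched chain does not recover the level of the ethoxy member, with the gap standing at a 55-fold higher number from compound 1 to compound 4 (1.74 log units; beyond the scatter). With 1-methylbutyl in place of heptyl, the step is an at least 1.0-fold lower number from compound 3 to compound 4 (0.00 log units; that floor lies within the scatter). This step cannot be read as a change, since compound 3 is held at a limit of the assay and not at a number: the limit of > 50000 nM in this assay, at which 1 of the 4 values shown sits.

Only one branched chain is shown, so it remains open whether the rise follows branching as such or a branch on the carbon bound to the oxygen. Also open, from the compounds shown here alone, is how an isopropyl group, or a chain ending in an amine or a carboxylic acid, would behave at this position.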